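Phenyl for Thiazolyl on the Amide Nitrogen

The source may report more compounds than this note shows. Statements on the series, on what has been measured and on what is new or still open speak of the compounds shown alone.

Compound 1 `Cc1nn(-c2ncnc3nc[nH]c23)c2c1C(OCc1ccc(C(C)C)cc1)CC(=O)N2`: 1690 nM
Compound 2 `Cc1nn(-c2ncnc3nc[nH]c23)c2c1C(C(=O)N(C)c1nccs1)CC(=O)N2`: 3300 nM

In a functional assay on HEK293 cells for agonist activity at G-protein coupled receptor 39 (Homo sapiens), read by scintillation proximity assay and inositol phosphate accumulation, with a stated time of 75 min (on this read-out lower numbers stand for an effect already at smaller amounts and higher numbers for an effect only at larger amounts of compound), compound 2 gives the higher of the two numbers, yet compound 1 lies within the scatter of it, so the two stand level. Compound 3 `Cc1nn(-c2ncnc3nc[nH]c23)c2c1C(C(=O)N(C)c1ccccc1)CC(=O)N2` differs from compound 2 by phenyl in place of 1,3-thiazol-2-yl on an amide-type nitrogen. For the measured compounds named here, no step between measured compounds bears on this change, so no step beyond the scatter is expected in either direction. Compound 3 is therefore expected to give 3000 nM, between 1000 nM and 9000 nM, a step of a 1.1-fold lower number from compound 2 to compound 3 (0.04 log units; within the scatter) that should stay within the scatter.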

Compound 3, half-maximal effective concentration: 5220 nM
Compound 3: the middle estimate sits 1.7-fold (0.24 log units) below what was measured; the range from low to high includes it.
By their numbers in this assay, from the lowest: compounds 1, 2 and 3 (each within the scatter of the next, the first and the last beyond it).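

In this assay, the change from 1,3-thiazol-2-yl to phenyl on the amide-type nitrogen gives a step that stays within the scatter (a 1.6-fold higher number from compound 2 to compound 3 (0.20 log units; within the scatter)). This pair shows that, at this position, the five-membered ring with its nitrogen and sulfur can give way to a six-membered ring of carbon only with no step beyond the scatter. No evidence here bears on why this is so.

As far as these compounds go, whether a pyridyl or cyclohexyl group on this nitrogen would stay within the scatter remains open. So does the outcome of replacing the methyl on this nitrogen with an ethyl group.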